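Thiosemicarbazone series: swapping the aryl group on the thiourea nitrogen

The source may report more compounds than this note shows. Statements on the series, on what has been measured and on what is new or still open speak of the compounds shown alone.

Among the measured compounds shown here, compound 1 `N#Cc1ccc(NC(=S)N/N=C/c2ccc3ccccc3n2)cc1` gives the only full number in the set: in a functional assay on HT-29 cells (Homo sapiens) for antiproliferative activity, read by sulforhodamine B assay, with a stated time of 72 h (on this read-out higher numbers stand for weaker inhibition and lower numbers for stronger inhibition), compound 1 gives 15600 nM. Compound 2 `Cc1ccc(NC(=O)N/N=C/c2ccc3ccccc3n2)cc1`, which carries a carbonyl in place of the thiocarbonyl as well as a 4-methylphenyl group, is reported in this assay only as a limit, > 100000 nM. The two compounds differ in more than one place, so their values are set side by side without a step between them; what is shown is the limit of > 100000 nM in this assay, at which 1 of the 2 values shown sits.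

Compound 3 `Cc1ccccc1NC(=S)N/N=C/c1ccc2ccccc2n1` is not yet measured in this assay. It differs from compound 1 by 2-methylphenyl in place of 4-cyanophenyl on an amide-type nitrogen. For the measured compounds named here, no measured step covers this change. The loss of the nitrile is expected to weaken inhibition beyond the usual scatter, giving a step of a 2.6-fold higher number from compound 1 to compound 3 (0.41 log units; beyond the scatter) from compound 1 to compound 3. Compound 3 is therefore estimated at 40000 nM, within a range from 12000 nM to 130000 nM.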

Compound 3, half-maximal inhibitory concentration: 42300 nM
Estimate against measurement, compound 3: 1.1-fold (0.02 log units) below, within the range that was stated.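

On the amide-type nitrogen whose other neighbour is the thiocarbonyl carbon, the aryl group can be changed with a measurable effect in this assay: 2-methylphenyl in place of 4-cyanophenyl gives a 2.7-fold higher number from compound 1 to compound 3 (0.43 log units; beyond the scatter). Among the compounds shown here, this is the first single-place step, and it is modest: compound 3 still reads as a full number, 42300 nM. No measurement shown gives a cause for this step, and within it the departure of the nitrile cannot be separated from the arrival of the methyl group.

On these data alone, whether an aromatic ring is needed on this nitrogen at all remains open. Also open, as far as these compounds go, is what an amine or a carboxylic acid on that ring, or a simple alkyl chain in its place, would do to the reading.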